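The source may hold more compounds than are shown below. What is called first, only, known or untested is meant among the compounds shown, and "the series" means these compounds.

Three compounds share one core and differ only in the group on one aromatic carbon. Compound 1 `Cc1cc(C)c(S(C)(=O)=O)cc1C(=O)N=C(N)N` carries a methyl there; in a functional assay for inhibition of sodium/hydrogen exchanger (Oryctolagus cuniculus) (on this read-out lower numbers stand for stronger inhibition and higher numbers for weaker inhibition), compound 1 gives 11 nM. Compound 2 `Cc1cc(-c2ccco2)c(S(C)(=O)=O)cc1C(=O)N=C(N)N` carries a furan-2-yl and gives 16 nM. Compound 3 `Cc1cc(Oc2ccccc2Cl)c(S(C)(=O)=O)cc1C(=O)N=C(N)N` carries a 2-chlorophenoxy and gives 14 nM. Every step between these three stays within the scatter: a 1.5-fold higher number from compound 1 to compound 2 (0.16 log units; within the scatter), a 1.3-fold higher number from compound 1 to compound 3 (0.10 log units; within the scatter) and a 1.1-fold lower number from compound 2 to compound 3 (0.06 log units; within the scatter). Compound 3 therefore sits within the scatter of both neighbours, closest to compound 2.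

Compound 4 `Cc1cc(Oc2cccnc2)c(S(C)(=O)=O)cc1C(=O)N=C(N)N` has not yet been measured. It differs from compound 3 in one place: pyridin-3-yl in place of 2-chlorophenyl on an oxygen on an aromatic ring. Within the data shown here, no measured step swaps the ring on that oxygen, so none bears on it directly; the only guide is that three rather different groups at this aromatic carbon, methyl, furan-2-yl and 2-chlorophenoxy, all gave numbers within the scatter of one another. The expected step is therefore no change at the digits printed from compound 3 to compound 4 (within the scatter), nothing beyond the scatter. Compound 4 is estimated at 14 nM, within a range of 7 nM to 28 nM.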

Compound 4, half-maximal inhibitory concentration: 8.8 nM
The estimate for compound 4 lay 1.6-fold (0.20 log units) above the measured number; low and high end bracket the measured number.
By their numbers in this assay, from the lowest: compounds 4, 1, 3 and 2 (each within the scatter of the next).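

Changing the ring on the oxygen is the first change shown that leaves the oxygen in place, and in this assay it gives a 1.6-fold lower number from compound 3 to compound 4 (0.20 log units; within the scatter), so pyridin-3-yl, which brings a ring nitrogen and loses the chlorine, is tolerated as well as 2-chlorophenyl. The (pyridin-3-yl)oxy group also fits the earlier picture at this aromatic carbon: replacing furan-2-yl gives a 1.8-fold lower number from compound 2 to compound 4 (0.26 log units; within the scatter) and replacing methyl gives a 1.3-fold lower number from compound 1 to compound 4 (0.10 log units; within the scatter), so all four groups shown lie within the scatter of one another. Nothing available explains this flat result.

The compounds shown leave open whether the same holds for an amine or a carboxylic acid on this aromatic carbon. They also leave open whether a longer chain in place of the ring on the oxygen would fit this picture.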